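Cytotoxicity notes: chloro for trifluoromethyl on the aryl ring

The source may hold more compounds than are shown below. What is called first, only, known or untested is meant among the compounds shown, and "the series" means these compounds.

Measured compounds:
compound 1, `CN1CCN(CCCNCc2cn(-c3ccc([N+](=O)[O-])cc3)nc2-c2ccc(Cl)cc2)CC1`, 3700 nM
compound 2, `CCCN1CCC(CNCc2cn(-c3ccc([N+](=O)[O-])cc3)nc2-c2ccc(C(F)(F)F)cc2)CC1`, 2300 nM
compound 3, `CN1CCN(CCNCc2cn(-c3ccc([N+](=O)[O-])cc3)nc2-c2ccc(C(F)(F)F)cc2)CC1`, 3200 nM

All three values come from an ADME assay on Huh-7 cells (Homo sapiens) for cytotoxicity; on this read-out lower numbers stand for higher toxicity in this test and higher numbers for lower toxicity in this test. Compound 2 gives 2300 nM in this assay, which is the lowest of the three numbers, but its separation from compound 3 and from compound 1 lies within the scatter, so no order among the three can be read from them. Within the data shown here, the one single-change step that has been measured, a 1.4-fold higher number from compound 2 to compound 3 (0.14 log units; within the scatter), is within the scatter as well.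

Compound 4, `CCCN1CCC(CNCc2cn(-c3ccc([N+](=O)[O-])cc3)nc2-c2ccc(Cl)cc2)CC1`, is yet to be measured in this assay. Against compound 2 the change is chloro in place of trifluoromethyl on an aromatic carbon.

Among the measured compounds shown here, no measured pair isolates this change. Compound 1 carries chloro and gives 3700 nM, while compound 3 carries trifluoromethyl and gives 3200 nM, and the two values sit within the scatter of each other, but those two compounds also differ in the chain on the amine nitrogen, so they only hint that the aryl substituent does not move this read-out much. On that basis the step of a 1.2-fold higher number from compound 2 to compound 4 (0.07 log units; within the scatter) is expected to stay within the scatter, with no direction favoured. Compound 4 is therefore estimated at 2700 nM, in the range 1300 nM to 5500 nM.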

Compound 4, half-maximal cytotoxic concentration: 11000 nM
Compound 4: the middle estimate sits 4.1-fold (0.61 log units) below what was measured; measured number above the stated range.
By their numbers in this assay, from the lowest: compounds 2, 3 and 1 (each within the scatter of the next); then compound 4.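

In this assay, the aryl substituent is not silent on this aromatic carbon, para to a large group: with the 1-propylpiperidin-4-yl side chain held constant, 4-chlorophenyl in place of 4-(trifluoromethyl)phenyl gives a 4.8-fold higher number from compound 2 to compound 4 (0.68 log units; beyond the scatter), a shift towards lower toxicity in this test. Among these compounds, the side chain also registers once the 4-chlorophenyl group is held constant, with a 3.0-fold higher number from compound 1 to compound 4 (0.47 log units; beyond the scatter), whereas the only earlier single-change step, a 1.4-fold higher number from compound 2 to compound 3 (0.14 log units; within the scatter), involved a different chain on a 4-(trifluoromethyl)phenyl compound and stayed within the scatter. Nothing available explains why either change moves this read-out.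

It remains open whether the chloro for trifluoromethyl step has the same size with a 4-methylpiperazin-1-yl side chain, since no matched pair on that chain appears among these compounds. Going by these compounds, it is also open whether fluoro, bromo or methoxy at the same place, with the 1-propylpiperidin-4-yl side chain kept, would track chloro or trifluoromethyl on this read-out.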